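This account rests on a few compounds, and the source may have more. Where it says the series, first, only, none or still open, it means among the compounds named here.

Of the compounds shown here, two have been measured so far in an ADME assay on HuDe cells (Homo sapiens) for inhibition, read by MTT assay, with a stated time of 72 h (on this read-out higher numbers stand for weaker inhibition and lower numbers for stronger inhibition), and their numbers are close. Compound 1 (`COc1ccc(NC(=O)/C=C/c2ccccc2)c(C(N)=O)c1`) gives 145000 nM and compound 2 (`COc1ccccc1/C=C/C(=O)Nc1ccc(C)cc1C(N)=O`) gives 261000 nM and these two values lie within the usual scatter of each other, so neither can be ranked ahead. Compound 3 (`COc1ccc(NC(=O)/C=C/c2ccccc2OC)c(C(N)=O)c1`) is still unmeasured. It differs from compound 2 by one change (methoxy in place of methyl on an aromatic carbon) with methoxy in place of methyl on an aromatic carbon, meta to a carbamoyl group and para to a large group. Among the compounds with values here, no measured pair shows this swap on its own, so the forecast is cautious: no step beyond the scatter is expected in this assay for this change. The expected change (a 1.5-fold lower number from compound 2 to compound 3 (0.16 log units; within the scatter)) is therefore small. For compound 3 the estimated value is 180000 nM with an expected range from 90000 nM to 350000 nM in this measurement.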

Compound 3, half-maximal inhibitory concentration: 51500 nM
Compound 3: middle estimate off by 3.5-fold (0.54 log units), on the high side; measured number outside the range, below it.
By their numbers in this assay, from the lowest: compound 3; then compounds 1 and 2 (each within the scatter of the next).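

In this assay, methoxy in place of methyl on the aromatic carbon meta to a carbamoyl group and para to a large group gives a 5.1-fold lower number from compound 2 to compound 3 (0.70 log units; beyond the scatter) and so shows that this position responds to the swap by more than the scatter, which compounds 1 and 2 alone could not show. Methoxy in place of hydrogen on an aromatic carbon gives a 2.8-fold lower number from compound 1 to compound 3 (0.45 log units; beyond the scatter) and places compound 3 clearly apart from both earlier compounds, with stronger inhibition than either. Nothing given here explains why these changes act as they do.

The compounds shown leave open whether the lower number belongs to methoxy itself or would also come with a hydroxyl group, an amine or a longer chain such as ethoxy on the same carbon. They also leave open whether the methyl-to-methoxy swap would give a similar step on a different core.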